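A few compounds are considered here, and "the series" means these few. Any claim that something is new, unique, unknown or untested is made for them only; others in the source may bear on it.

Measured compounds:
- compound 1 `CN(C)C(=O)c1cc2cnc(Nc3ccc(NC(=O)C4(C(=O)Nc5ccc(F)cc5)CC4)cc3F)nc2n1C1CCCC1` — 82.6%
- compound 2 `CN(C)C(=O)c1cc2cnc(Nc3ccc(NC(=O)C4(C(=O)Nc5ccc(Br)cc5)CC4)cc3)nc2n1C1CCCC1` — 76.9%
- compound 3 `CN(C)C(=O)c1cc2cnc(Nc3ccc(NC(=O)C4(C(=O)Nc5cccc(Cl)c5)CC4)cc3)nc2n1C1CCCC1` — 84.1%

In a functional assay on NCI-H1299 cells (Homo sapiens) for inhibition, read by CCK-8 assay, with a stated time of 72 h, tested at 10 uM (on this read-out higher numbers stand for more inhibition of growth at the one concentration tested and lower numbers for less inhibition of growth), compound 1 gives 82.6%, compound 2 gives 76.9% and compound 3 gives 84.1%. Compound 2 carries the lowest of the three numbers, but its gaps to compound 1 and to compound 3 both sit within the scatter, so no ordering among the three can be claimed.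

The next compound, compound 4 `CN(C)C(=O)c1cc2cnc(Nc3ccc(NC(=O)C4(C(=O)Nc5cccc(Br)c5)CC4)cc3)nc2n1C1CCCC1`, differs from compound 2 by 3-bromophenyl in place of 4-bromophenyl on an amide-type nitrogen. Among the compounds with values here, one measured step bears on this: a number 7.2 percentage points higher from compound 2 to compound 3 (within the scatter), which places a halogen at the 3-position of the phenyl on the same amide-type nitrogen in place of a 4-halogen and stays within the scatter. That change also swaps chlorine for bromine, so it is only an indirect guide. On this basis the expected step in this assay from compound 2 to compound 4 is small, a number 3.1 percentage points higher from compound 2 to compound 4 (within the scatter), not beyond the scatter in either direction. Compound 4 is therefore estimated at 80%, with a range from 70% to 90%.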

Compound 4, percent growth inhibition at one concentration: 77.5%
The estimate for compound 4 lay 2.5 percentage points above the measured number; low and high end bracket the measured number.
By their numbers in this assay, from the lowest: compounds 2, 4, 1 and 3 (each within the scatter of the next).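

In this assay, the bromine's place on the phenyl ring is now isolated: a number 0.6 percentage points higher from compound 2 to compound 4 (within the scatter), so 3-bromophenyl and 4-bromophenyl on the amide-type nitrogen cannot be told apart here, which the earlier step, with its halogen also changing, could not show. With that place held, bromo in place of chloro on an aromatic carbon gives a number 6.6 percentage points lower from compound 3 to compound 4 (within the scatter), so within these compounds neither the halogen's place nor its identity separates the numbers. No measurement at hand bears on the reason for these numbers.

Open, on these data alone, is whether a group other than a halogen on this phenyl, such as methoxy, nitrile or dimethylamino, would move the number beyond the scatter. A single tested concentration also leaves open whether these compounds would separate at lower concentrations.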